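The source may report more compounds than this note shows. Statements on the series, on what has been measured and on what is new or still open speak of the compounds shown alone.

Measured compounds in an assay on isolated protein for binding affinity to leukotriene B4 receptor 1 (Homo sapiens), tested at 1 uM; on this read-out higher numbers stand for more inhibition at the one concentration tested (going by the name of the read-out) and lower numbers for less inhibition:
Compound 1 `CCc1cc(C(C)=O)c(O)cc1OCCCCCCC#N` gives 73%.
Compound 2 `CCc1cc(C(C)=O)c(O)cc1OCCCCCCCC(C)(C)C#N` gives 29%.
Compound 3 `CCc1cc(C(C)=O)c(O)cc1OCCCCCCC(=O)Nc1nn[nH]n1` gives 83%.

Compound 3 has the highest of the three numbers: its separation from compound 1 is within the scatter, while its separation from compound 2 is beyond it. The step to the unmeasured compound 4 `CCc1cc(C(C)=O)c(O)cc1OCCCCCCc1nnn[nH]1` is 1H-tetrazol-5-yl in place of (2H-tetrazol-5-yl)carbamoyl on a saturated chain carbon, six bonds along the chain from an oxygen on an aromatic ring.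

Within the data shown here, two measured steps bear on this change. The step of a number 10 percentage points higher from compound 1 to compound 3 (within the scatter) shows that a tetrazole-bearing end and a plain nitrile end behave alike, whereas the step of a number 54 percentage points higher from compound 2 to compound 3 (beyond the scatter) shows the only large loss comes with the branched 2-cyano-2-methylpropyl end. Since compound 4 keeps a tetrazole on an unbranched chain, the step of a number 8 percentage points lower from compound 3 to compound 4 (within the scatter) is expected to stay within the scatter. Compound 4 is therefore estimated at 75%, with a range from 50% to 92%.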

Compound 4, a percentage reported as inhibition, at one concentration (the size of the read-out at that concentration, not a potency): 60%
For compound 4 the middle estimate is 15 percentage points above the measured one, and the stated range covers the measured number.
By their numbers in this assay, from the lowest: compound 2; then compound 4; then compounds 1 and 3 (each within the scatter of the next).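

In this assay, the tetrazole end does not settle the result by itself: 1H-tetrazol-5-yl in place of (2H-tetrazol-5-yl)carbamoyl gives a number 23 percentage points lower from compound 3 to compound 4 (beyond the scatter), and in place of cyano it gives a number 13 percentage points lower from compound 1 to compound 4 (beyond the scatter). The earlier closeness of the nitrile and tetrazole-bearing ends therefore does not extend to every tetrazole end at this place. The branched 2-cyano-2-methylpropyl end still stands lowest, with a number 31 percentage points higher from compound 2 to compound 4 (beyond the scatter).

On these data alone, whether a carboxylic acid or a longer chain carrying the 1H-tetrazol-5-yl would recover the higher numbers stays open. Nothing available explains these steps.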